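This account rests on a few compounds, and the source may have more. Where it says the series, first, only, none or still open, it means among the compounds named here.

Working notes on the series. Within the data shown here, in an assay on isolated protein (Oryctolagus cuniculus) with Thromboxane-A synthase (Homo sapiens) as the target, tested at 1 uM (a higher number here means more inhibition at the concentration tested (going by the name of the read-out), a lower number less inhibition), compound 1 `CC(C)n1nc(-c2cccnc2)c2ccccc2c1=O` gives 87%, the second highest of the three numbers so far. Compound 2 `CCCCn1nc(-c2cccnc2)c2ccccc2c1=O` gives 91%, and the step of a number 4 percentage points higher from compound 1 to compound 2 (within the scatter) stays within the scatter. Compound 3 `CCOC(=O)Cn1nc(-c2cccnc2)c2ccccc2c1=O` gives 28%; the step of a number 59 percentage points lower from compound 1 to compound 3 (beyond the scatter) is large, as is a number 63 percentage points lower from compound 2 to compound 3 (beyond the scatter).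

Compound 4 `O=c1c2ccccc2c(-c2cccnc2)nn1CCO` is not yet measured in this assay. It differs from compound 1 as follows: 2-hydroxyethyl in place of isopropyl on an aromatic nitrogen. Among the measured compounds shown here, two measured steps bear on it. The step to compound 2 shows that exchanging one plain chain for another leaves the read-out unchanged. The step to compound 3 shows that a chain bearing oxygen on the same aromatic nitrogen brings a large loss. The entering 2-hydroxyethyl carries one hydrogen-bond donor and one acceptor, as counted, while being no larger than the leaving isopropyl. The expectation for compound 4 is therefore a loss beyond the scatter, smaller than that seen with compound 3 because a number 59 percentage points lower from compound 1 to compound 3 (beyond the scatter) came with a larger group. Compound 4 is expected to give 50%, in the range 25% to 78%, an expected step of a number 37 percentage points lower from compound 1 to compound 4 (beyond the scatter).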

Compound 4, a percentage reported as inhibition, at one concentration (the size of the read-out at that concentration, not a potency): 69%
For compound 4 the middle estimate is 19 percentage points below the measured one, within the range that was stated.
By their numbers in this assay, from the lowest: compound 3; then compound 4; then compounds 1 and 2 (each within the scatter of the next).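

In this assay an oxygen-bearing chain on this aromatic nitrogen need not bring a large loss: 2-hydroxyethyl in place of isopropyl gives a number 18 percentage points lower from compound 1 to compound 4 (beyond the scatter) and stays a modest step, and hydroxy in place of ethyl on the butyl chain gives a number 22 percentage points lower from compound 2 to compound 4 (beyond the scatter) and is also modest. The two oxygen-bearing chains themselves differ widely, with a number 41 percentage points higher from compound 3 to compound 4 (beyond the scatter) as a large step, so the presence of oxygen alone does not set the size of the loss across compounds 1 to 4. Nothing at hand accounts for this difference.

Going by these compounds, it remains open whether an amine or a carboxylic acid on the same chain would read closer to compound 3 or to compound 4. On these data alone, a longer chain ending in hydroxy, or a methoxyethyl chain, also remains untested against the plain butyl chain of compound 2 in this series.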